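The source may hold more compounds than are shown below. What is called first, only, known or untested is meant among the compounds shown, and "the series" means these compounds.

Measured in a functional assay on OVCAR-3 cells (Homo sapiens) for antiproliferative activity, read by MTT assay, with a stated time of 24 h (a lower number here means a stronger inhibitor, a higher number a weaker inhibitor), each value being a limit of the assay:

Compound 1 `Cc1cccc(NNC(=O)c2ccc(NS(=O)(=O)c3cnc(O)nc3O)cc2)c1`: > 20000 nM
Compound 2 `O=C(NNc1ccc(F)cc1)c1ccc(NS(=O)(=O)c2cnc(O)nc2O)cc1`: > 20000 nM
Compound 3 `Cc1ccccc1NNC(=O)c1cccc(NS(=O)(=O)c2cnc(O)nc2O)c1`: > 20000 nM

None of these three results is a number, and together they come to the limit of > 20000 nM in this assay, at which 3 of the 3 values shown sit. Compound 3 therefore has no exact place in the series, only its limit.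

Compound 4 `O=C(NNc1ccccc1Cl)c1cccc(NS(=O)(=O)c2cnc(O)nc2O)c1` differs from compound 3 by a single exchange: chloro in place of methyl on an aromatic carbon, ortho to a large group, which turns 2-methylphenyl into 2-chlorophenyl (chloro in place of methyl on an aromatic carbon).

Going by the values given here, only one measured step lies near this change, a step that the two limits leave unreadable from compound 1 to compound 2. It concerns a different exchange, and with a limit at each end it offers no size to carry over. The expectation thus rests mainly on compound 3, whose limit is > 20000 nM. No step beyond the scatter is expected in this assay, and no direction can be assigned. Compound 4 will most likely also be reported only as a limit.

The expected step is a step that the limit leaves unreadable from compound 3 to compound 4.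

For compound 4 the estimated value is 25000 nM, with an expected range from 10000 nM to 60000 nM.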

Compound 4, half-maximal inhibitory concentration: 3350 nM
Estimate against measurement, compound 4: 7.5-fold (0.87 log units) above; the whole stated range lies above it.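

In this assay, chloro in place of methyl on an aromatic carbon, ortho to a large group, gives an at least 5.9-fold lower number from compound 3 to compound 4 (0.77 log units; beyond the scatter). This is the only readable step among the compounds shown, and it shows that this position is not silent in this assay: an exchange of one heavy atom for one heavy atom, with no ring, no hydrogen-bond donor or acceptor and no net charge on either side, is enough to take compound 4 off the limit and give it a numerical value. The other results remain limits of the assay and not numbers: the limit of > 20000 nM in this assay, at which 3 of the 4 values shown sit.

On these data alone, the full size of the step stays open, as compound 3 has only a limit, and one exchange cannot show whether the result is particular to chloro. Also open, as far as these compounds go, is whether bromo, methoxy or trifluoromethyl on this same aromatic carbon would give a numerical value in this assay, and whether chloro would do so on the 2-substituted phenyl ring of a compound with the arrangement of compound 1.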